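A few compounds are considered here, and "the series" means these few. Any claim that something is new, unique, unknown or untested is made for them only; others in the source may bear on it.

Compound 1, `CC(C)c1cccc(C(C)C)c1OC(=O)NC(=O)OCCCc1ccccc1`: 660 nM
Compound 2, `CCCCCCOC(=O)NC(=O)Oc1c(C(C)C)cccc1C(C)C`: 53 nM

In an assay on microsomes from intestine for inhibition of acyl-CoA:cholesterol acyltransferase (Oryctolagus cuniculus) (a lower number here means a stronger inhibitor, a higher number a weaker inhibitor), compound 2 gives the lower of the two numbers; the step of a 12-fold lower number from compound 1 to compound 2 (1.10 log units; beyond the scatter) sets it apart from compound 1. Compound 3, `CCCCCCCCOC(=O)NC(=O)Oc1c(C(C)C)cccc1C(C)C`, carries ethyl in place of hydrogen on a saturated chain carbon, six bonds along the chain from an oxygen next to a carbonyl group. Among the compounds with values here, no measured step varies the chain length itself; the step from compound 1 to compound 2 exchanged a ring for a saturated chain fragment and bears on this change only loosely. The expected change a 1.3-fold lower number from compound 2 to compound 3 (0.12 log units; within the scatter) for compound 3 is therefore small, likely within the scatter. Compound 3 is estimated at 40 nM, in the range 15 nM to 120 nM.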

Compound 3, half-maximal inhibitory concentration: 250 nM
Estimate against measurement, compound 3: 6.3-fold (0.80 log units) below; the measured number lies above the stated range.
By their numbers in this assay, from the lowest: compound 2; then compound 3; then compound 1.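

In this assay, the added ethyl, on a saturated chain carbon six bonds along the chain from an oxygen next to a carbonyl group, gives a 4.7-fold higher number from compound 2 to compound 3 (0.67 log units; beyond the scatter) and shows that chain length at this position matters. Pentyl in place of phenyl still gives a 2.6-fold lower number from compound 1 to compound 3 (0.42 log units; beyond the scatter), which keeps only part of the gain in a 12-fold lower number from compound 1 to compound 2 (1.10 log units; beyond the scatter). Nothing shown accounts for this reversal. Going by these compounds, whether a shorter chain, or a chain ending in an amine or a carboxylic acid, would give a lower number stays open.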